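This account rests on a few compounds, and the source may have more. Where it says the series, first, only, none or still open, it means among the compounds named here.

Measured so far in a functional assay on PC-3 cells (Homo sapiens) for antiproliferative activity, read by MTT assay, with a stated time of 72 h; a lower number here means a stronger inhibitor, a higher number a weaker inhibitor:
compound 1, `C=CC(=O)Nc1cc2c(N3CCc4ccccc43)ncnc2cc1OC`: 5940 nM
compound 2, `COc1cc2ncnc(N3CCc4ccccc43)c2cc1NC(=O)/C=C/C(C)C`: 6530 nM
compound 3, `C=CC(=O)Nc1cc2c(N3CCc4ccccc43)ncnc2cc1O[C@@H]1CCOC1`: 2710 nM

Compound 3 holds the lowest number of the three. Its nearest neighbour is compound 1, and the step of a 2.2-fold lower number from compound 1 to compound 3 (0.34 log units; beyond the scatter) is modest but beyond the scatter. Compound 2 lies furthest from compound 3; the step of a 1.1-fold higher number from compound 1 to compound 2 (0.04 log units; within the scatter), in which the group on the carbonyl carbon was lengthened, stays within the scatter.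

Compound 4, `CCC/C=C/C(=O)Nc1cc2c(N3CCc4ccccc43)ncnc2cc1O[C@@H]1CCOC1`, differs from compound 3 as follows: pent-1-en-1-yl in place of vinyl on a carbonyl carbon. Within the data shown here, the one measured step that bears on this change is the lengthening of the same group on the carbonyl carbon, a 1.1-fold higher number from compound 1 to compound 2 (0.04 log units; within the scatter), which produced no movement beyond the scatter. Pent-1-en-1-yl is an enlargement of the same kind at the same place, so no step beyond the scatter is expected in this assay, with the direction, if any, toward a slightly higher number as seen in the move from compound 1 to compound 2.

For compound 4 the expected value in this assay is 3200 nM, with a range from 1500 nM to 7000 nM. The expected step from compound 3 is a 1.2-fold higher number from compound 3 to compound 4 (0.07 log units; within the scatter).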

Compound 4, half-maximal inhibitory concentration: 9230 nM
Estimate against measurement, compound 4: 2.9-fold (0.46 log units) below, outside the stated range (above it).
By their numbers in this assay, from the lowest: compound 3; then compounds 1, 2 and 4 (each within the scatter of the next).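

In this assay, the group on the carbonyl carbon turns out to matter: pent-1-en-1-yl in place of vinyl gives a modest step beyond the scatter (a 3.4-fold higher number from compound 3 to compound 4 (0.53 log units; beyond the scatter)). The earlier change at this place, 3-methylbut-1-en-1-yl in place of vinyl with methyl on the oxygen, stayed within the scatter (a 1.1-fold higher number from compound 1 to compound 2 (0.04 log units; within the scatter)), so enlarging this group can no longer be treated as neutral across the series, and compound 2 now stands as the exception to any rule that enlargement raises the number beyond the scatter. No measurement at hand accounts for the difference between these two steps.

The two steps differ both in the chain entering on the carbonyl carbon and in the group on the oxygen, so the shown compounds cannot separate the branched from the unbranched chain, or methyl from oxolan-3-yl, as what decides the size of the step. Also open, on these data alone, is how a chain carrying an amine, or a shorter chain such as prop-1-en-1-yl, would read on the carbonyl carbon in this assay.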